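Trimming an Ethyl from a Saturated Chain

This account rests on a few compounds, and the source may have more. Where it says the series, first, only, none or still open, it means among the compounds named here.

Measured so far:
compound 1, `CCCCCCNc1cncc(C(=O)NCc2ccccc2)n1`, in an ADME assay on HeLa cells (Homo sapiens) for cytotoxicity, read by microscopy, with a stated time of 6 days (a higher number here means that more compound is tolerated, a lower number that less compound is tolerated), compound 1 gives > 100000 nM, a limit of the assay.
compound 2, `CCCCCCNc1nccnc1C(=O)NCc1ccccc1`, in this assay compound 2 gives > 100000 nM, also a limit.

Compound 1 therefore stands at the limit of > 100000 nM in this assay, at which 2 of the 2 values shown sit, and no number beneath that limit is known for it. For the measured compounds named here, compound 2 sits at the same limit, so the two values show only that neither compound reached a cytotoxic concentration within the tested range.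

Compound 3, `CCCCNc1cncc(C(=O)NCc2ccccc2)n1`, differs from compound 1 by hydrogen in place of ethyl on a saturated chain carbon, four bonds along the chain from a nitrogen on an aromatic ring. Going by the values given here, no measured step between compounds covers a change of this kind, so the expectation rests on compound 1 alone. In this assay the step of a number no higher from compound 1 to compound 3 (the limit leaves the size open) is expected to be none beyond the usual scatter. Compound 3 is thus estimated at 100000 nM, between 40000 nM and 300000 nM, most likely again reported only as a limit.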

Compound 3, minimum cytotoxic concentration: > 100000 nM
Compound 3 ended at the assay's limit; the forecaster's own chance of this, stated with the estimate: 80%; the middle value lies on the limit itself.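

No step can be read between compound 1 and compound 3, because both values are limits and not numbers: the limit of > 100000 nM in this assay, at which 3 of the 3 values shown sit.

The compounds shown leave open at what concentration any of them would become cytotoxic, and so whether hydrogen in place of ethyl changes how much compound is tolerated.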